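Ethoxy in Place of Methoxy: An Untested Step

A few compounds are considered here, and "the series" means these few. Any claim that something is new, unique, unknown or untested is made for them only; others in the source may bear on it.

Compound 1 `CCCCCCCCCCCCCCCCCCNC(=O)[C@@H]1CSC(c2ccc(OC)cc2)N1` is the weaker of the two compounds measured in a functional assay on TSU-Pr1 cells (Homo sapiens) for antiproliferative activity, read by sulforhodamine B assay (a lower number here means a stronger inhibitor, a higher number a weaker inhibitor), where compound 1 gives 19600 nM. Compound 2 `CCCCCCCCCCCCCCCCCCNC(=O)[C@@H]1CSC(c2ccc(N(C)C)cc2)N1` gives 3000 nM, a change of a 6.5-fold lower number from compound 1 to compound 2 (0.82 log units; beyond the scatter) brought by a dimethylamino in place of methoxy on an aromatic carbon. Compound 3 `CCCCCCCCCCCCCCCCCCNC(=O)[C@@H]1CSC(c2ccc(OCC)cc2)N1` differs from compound 1 by methyl in place of hydrogen on a saturated chain carbon bound to an oxygen on an aromatic ring, methoxy to ethoxy. Among the measured compounds shown here, no measured step mirrors this change; the only step seen concerns a different group and offers no direct guide. Compound 3 is therefore expected to change little, with a step of a 1.3-fold lower number from compound 1 to compound 3 (0.12 log units; within the scatter) that stays within the scatter and an estimated 15000 nM, ranging from 5000 nM to 45000 nM.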

Compound 3, half-maximal inhibitory concentration: > 20000 nM
Compound 3 ended at the assay's limit; the forecaster's own chance of this, stated with the estimate: 10%; at least 1.3-fold (0.12 log units) between middle value and limit.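

In this assay compound 3 reads > 20000 nM, which is a limit and not a number: the limit of > 20000 nM in this assay, at which 1 of the 3 values shown sits.

Going from methoxy to ethoxy brought no visible gain, with an at least 1.0-fold higher number from compound 1 to compound 3 (0.00 log units; that floor lies within the scatter), so the true size of this step stays unknown. Ethoxy also falls clearly behind dimethylamino on this aromatic carbon, with an at least 6.6-fold higher number from compound 2 to compound 3 (0.82 log units; beyond the scatter), so among these three compounds only dimethylamino gives a clearly lower number.

From the compounds shown here alone, whether diethylamino or a plain amino group in the same place would match compound 2 remains open, as does the effect of a longer chain such as propoxy.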